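Trimming a Methyl on Two Weakly Active Cores

The source may hold more compounds than are shown below. What is called first, only, known or untested is meant among the compounds shown, and "the series" means these compounds.

Compound 1 `CC(C)C(NC(=O)NO)C(=O)NC1CCCCC1`, compound 2 `CCC(C)C(NC(=O)NO)C(=O)NC1CCCCC1` and compound 3 `CCC(C)C1NC(=O)N(C2CCCC2)C1=O` have been tested in a functional assay on WI-38 cells (Homo sapiens) for inhibition (on this read-out higher numbers stand for weaker inhibition and lower numbers for stronger inhibition), while compound 4 `CC(C)C1NC(=O)N(C2CCCC2)C1=O` has not. In this assay compound 1 gives 58800 nM. For compound 2 only a limit is reported, > 100000 nM. For compound 3 too only a limit is reported, > 100000 nM, which is the limit of > 100000 nM in this assay, at which 2 of the 3 values shown sit. The change hydrogen in place of methyl on a saturated chain carbon, three bonds along the chain from an amide-type nitrogen and a carbonyl carbon gives an at least 1.7-fold lower number from compound 2 to compound 1 (0.23 log units; that floor lies within the scatter). Compound 4 carries the same kind of change, (hydrogen in place of methyl on a saturated chain carbon, two bonds along the chain from a saturated ring carbon), on the core of compound 3, though the place here is two bonds along the chain from a saturated ring carbon rather than three bonds along the chain from an amide-type nitrogen and a carbonyl carbon. How the cores of compound 2 and compound 3 differ is not broken down here. For compound 4 a step of a number no higher from compound 3 to compound 4 (the limit leaves the size open) is expected because an at least 1.7-fold lower number from compound 2 to compound 1 (0.23 log units; that floor lies within the scatter) was small. In this assay compound 4 is thus estimated at 100000 nM, between 40000 nM and 300000 nM.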

Compound 4, half-maximal inhibitory concentration: > 100000 nM
Compound 4: a limit, no number (the forecaster's own chance of this, stated with the estimate: 60%); the middle value sits exactly at the limit.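

No step can be read from compound 3 to compound 4, as both values are limits and not numbers: the limit of > 100000 nM in this assay, at which 3 of the 4 values shown sit. The compounds shown leave open whether hydrogen in place of methyl changes inhibition at all on the core of compound 3.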